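Trifluoromethyl in Place of Cyano on a Salicylanilide

The source may hold more compounds than are shown below. What is called first, only, known or untested is meant among the compounds shown, and "the series" means these compounds.

Compound 1, `O=C(Nc1cc(F)ccc1F)c1cc(-c2ccc(F)cc2F)ccc1O`, gives 3670 nM in a functional assay on RAW264.7 cells (Mus musculus) for inhibition, with a stated time of 4 days; a lower number here means a stronger inhibitor, a higher number a weaker inhibitor.
Compound 2, `N#Cc1cccc(NC(=O)c2cc(-c3ccc(F)cc3F)ccc2O)c1`, gives 2960 nM.
Compound 3, `O=C(Nc1ccc(Cl)cc1F)c1ccccc1O`, gives only a limit, > 10000 nM.

For the measured compounds named here, of the two numbers, compound 2 carries the smaller one, yet the only measured step, a 1.2-fold lower number from compound 1 to compound 2 (0.09 log units; within the scatter), is within the scatter, so the two compounds cannot be told apart. The value of compound 3 is a limit and not a number (the limit of > 10000 nM in this assay, at which 1 of the 3 values shown sits), so it says nothing about the size of any step.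

Compound 4, `O=C(Nc1cccc(C(F)(F)F)c1)c1cc(-c2ccc(F)cc2F)ccc1O`, differs from compound 2 by trifluoromethyl in place of cyano on an aromatic carbon. Going by the values given here, the one step measured on the ring attached to the amide-type nitrogen, a 1.2-fold lower number from compound 1 to compound 2 (0.09 log units; within the scatter), exchanged a whole set of groups there and still stayed within the scatter. Nothing measured speaks for a large change in either direction. Compound 4 is therefore expected to give 3000 nM, somewhere between 1000 nM and 9000 nM. The estimated step is a 1.0-fold higher number from compound 2 to compound 4 (0.01 log units; within the scatter), no more than the scatter.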

Compound 4, half-maximal inhibitory concentration: 4570 nM
The estimate for compound 4 lay 1.5-fold (0.18 log units) below the measured number; low and high end bracket the measured number.
By their numbers in this assay, from the lowest: compounds 2, 1 and 4 (each within the scatter of the next). At a limit, above all of these: compound 3.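

For the compounds shown here, the one earlier step on this ring swapped a whole set of groups, whereas this one exchanges a single group on an aromatic carbon, meta to a large group, and in this assay it gives a 1.5-fold higher number from compound 2 to compound 4 (0.19 log units; within the scatter) and so stays within the scatter. At this position, then, cyano and trifluoromethyl cannot be told apart, even though the incoming group has more heavy atoms and the leaving group carries a hydrogen-bond acceptor that the incoming group lacks. No measurement shown here offers a reason for this result.

On these data alone, whether an amine or a carboxylic acid on this same carbon would also stay within the scatter of compound 2 remains open. Also open, as far as these compounds go, is whether trifluoromethyl would give a similar number on a different carbon of the ring.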